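The source may hold more compounds than are shown below. What is called first, only, known or untested is meant among the compounds shown, and "the series" means these compounds.

Within the data shown here, in an ADME assay on MT4 cells (Homo sapiens) for cytotoxicity, read by MTT assay, with a stated time of 4 days (a higher number here means that more compound is tolerated, a lower number that less compound is tolerated), two compounds have numbers so far. Compound 1 (`CC(=O)Nc1ccc(O)c(C(=O)/C=C/c2ccc(F)cc2)c1`) gives 41100 nM. Compound 2 (`CC(=O)Nc1ccc2oc(-c3ccccc3)cc(=O)c2c1`) gives 184000 nM, the higher of the two numbers, and the gap between them lies beyond the usual scatter of repeated measurements. Compound 3 (`COc1cccc(-c2cc(=O)c3cc(NC(C)=O)ccc3o2)c1`) has yet to be measured in this assay. It differs from compound 2 in one place: methoxy in place of hydrogen on an aromatic carbon. In words, methoxy stands in place of hydrogen on an aromatic carbon of a six-membered aromatic ring of carbon only, meta to a large group.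

Among the measured compounds shown here, no measured pair differs in a single place, so the data offer no direct guide to the size of this step. A small fall in this assay is expected, probably not beyond the scatter, and this expectation rests only on compound 2 standing at 184000 nM, the higher of just two numbers. This estimate means an expected step of a 1.5-fold lower number from compound 2 to compound 3 (0.19 log units; within the scatter). Compound 3 is estimated at 120000 nM, with an expected range from 45000 nM to 300000 nM.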

Compound 3, half-maximal cytotoxic concentration: > 404000 nM
Compound 3 was reported as a limit; the forecaster's own chance of this, stated with the estimate: 20%; at least 3.3-fold (0.52 log units) between middle value and limit.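

In this assay, placing methoxy in place of hydrogen on an aromatic carbon, meta to a large group, gives an at least 2.1-fold higher number from compound 2 to compound 3 (0.34 log units; beyond the scatter), so this change on the six-membered aromatic ring of carbon only goes with more compound being tolerated, not less. Among these compounds, this is the first pair differing in one place, and so the first direct reading of what a single change does in this assay; it shows that this position accepts a group of two heavy atoms with no loss of tolerance. Compound 3 gives > 404000 nM, which is a limit of the assay and not a number, so the step has a lower bound but no known full size: the limit of > 404000 nM in this assay, at which 1 of the 3 values shown sits.

The compounds shown leave open whether the same step would follow from another group at this place, such as hydroxy, an amine, a carboxylic acid or a longer alkoxy chain, or whether it belongs to methoxy alone. They also leave open whether methoxy would give a similar step on another carbon of the same ring, since this single pair speaks for one place only.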